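This account rests on a few compounds, and the source may have more. Where it says the series, first, only, none or still open, it means among the compounds named here.

Compound 1, `COc1ccccc1-c1cnc(N)nc1-c1ccccc1`, gives 20%.
Compound 2, `COc1cccc(-c2cnc(N)nc2-c2ccccc2)c1`, is reported only as a limit, > 80%.
Compound 3, `O=C(Nc1ncc(-c2cccc(Cl)c2)c(-c2ccccc2)n1)C1CCC1`, gives 52%.

All three were tested in an assay on CHO cells for displacement of a labelled ligand from adenosine receptor A1 (Homo sapiens), read by scintillation counting, with a stated time of 1 h, tested at 1 uM; a higher number here means more inhibition at the concentration tested (going by the name of the read-out), a lower number less inhibition. Among the two numbers given, compound 3 stands highest; the nearest is compound 1, whose value lies lower, a gap beyond the scatter. The value of compound 2 is a limit of the assay and not a number, as noted in the limit of > 80% in this assay, at which 1 of the 3 values shown sits.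

The account now turns to compound 4, `OCCCNc1ncc(-c2cccc(Cl)c2)c(-c2ccccc2)n1`, which is not yet measured. It differs from compound 3 in one place: 3-hydroxypropyl in place of cyclobutylcarbonyl on a nitrogen on an aromatic ring. Within the data shown here, no measured pair in this set isolates this change, so the size of the step is open. Compound 4 is expected to sit somewhat below compound 3, a step of a number 12 percentage points lower from compound 3 to compound 4 (beyond the scatter) that may still fall inside the scatter. Compound 4 is therefore estimated at 40% in this assay, within a range from 15% to 70%.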

Compound 4, a percentage reported as inhibition, at one concentration (the size of the read-out at that concentration, not a potency): > 80%
Compound 4: a limit, no number; the forecaster's own chance of this, stated with the estimate: 10%; at least 40 percentage points between middle value and limit.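

In this assay compound 4 is reported as > 80%, which is a limit of the assay and not a number. Among these compounds, putting 3-hydroxypropyl in place of cyclobutylcarbonyl on a nitrogen on an aromatic ring is a step of a number at least 28 percentage points higher from compound 3 to compound 4 (beyond the scatter), the first evidence in this set that the group on this nitrogen changes the read-out and that neither the carbonyl nor the four-membered ring of cyclobutylcarbonyl is needed to reach this level of inhibition. The full size of the step cannot be read from this value: the limit of > 80% in this assay, at which 2 of the 4 values shown sit.

Among the compounds shown here, the single pair changes the carbonyl, the ring and the hydroxyl together, and it does not tell which of them carries the step. On these data alone, how a plain propyl group, a longer chain ending in hydroxyl, or an amine in place of the hydroxyl would read at this nitrogen remains open.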